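Cytotoxicity on Vero Cells: From Compound 3 to Compound 4

The compounds below may be only part of what the source reports. "The series", "measured", "known", "first", "only" and "open" are said of these compounds alone.

Four compounds share one core. Compound 1 `C[C@]1(CN2CCc3nc(-c4ccc(F)c(F)c4)oc3C2)Cn2cc([N+](=O)[O-])nc2O1`, compound 2 `C[C@]1(CN2CCn3cc(-c4ccc(F)c(F)c4)nc3C2)Cn2cc([N+](=O)[O-])nc2O1` and compound 3 `C[C@]1(CN2CCc3nc(N4CCCCC4)ccc3C2)Cn2cc([N+](=O)[O-])nc2O1` have been examined in an ADME assay on Vero cells (Chlorocebus sabaeus) for cytotoxicity, read by MTT assay, with a stated time of 72 h (a lower number here means that less compound is tolerated, a higher number that more compound is tolerated), while compound 4 `C[C@]1(CN2CCc3nc(-c4ccc(F)c(Cl)c4)ccc3C2)Cn2cc([N+](=O)[O-])nc2O1` has not. In this assay compound 1 reached only a limit of the assay, > 32 ug/mL, and not a number. For compound 2 the result is "not determined" (no result reported). Compound 3 stands without a single number, "not determined" (no result reported). Of the other two entries one is a limit of > 32 ug/mL in this assay, at which 1 of the 3 values shown sits, and one has no number either. Compound 4 differs from compound 3 by 3-chloro-4-fluorophenyl in place of piperidin-1-yl on an aromatic carbon. Among the compounds with values here, with no measured step to lean on, the size and direction of the change cannot be judged beyond the scatter. Compound 4 is expected to give about 32 ug/mL, between 12 ug/mL and 80 ug/mL.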

Compound 4, half-maximal cytotoxic concentration: > 32 ug/mL
Compound 4 was reported as a limit; the forecaster's own chance of this, stated with the estimate: 65%; the middle value lies on the limit itself.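

In this assay compound 4 gives > 32 ug/mL, a limit of the assay and not a number. Within the data shown here, compound 3 has no number either, so no step between compound 3 and compound 4 can be read. Going by these compounds, what replacing piperidin-1-yl with 3-chloro-4-fluorophenyl does to cytotoxicity stays open.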